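Swapping a branched pentyl group on two related cores

A few compounds are considered here, and "the series" means these few. Any claim that something is new, unique, unknown or untested is made for them only; others in the source may bear on it.

Compound 2 `CCC(C)(C)/N=C(\NC#N)Nc1ccncc1` and compound 1 `CCC(CC)/N=C(\NC#N)Nc1ccncc1` share one core and differ only by pentan-3-yl in place of 1,1-dimethylpropyl on a double-bonded nitrogen. In a functional assay on the whole organism (blood, strain Wistar-Okamoto) with Rattus norvegicus as the target, with a stated time of 5 days (on this read-out higher numbers stand for an effect only at larger amounts of compound and lower numbers for an effect already at smaller amounts), compound 2 gives 2.5 mg/kg, and compound 1 gives 2.5 mg/kg, so the step of no change at the digits printed from compound 2 to compound 1 (within the scatter). Compound 3 `CCC(C)(C)N/C(=N\O)Nc1cccnc1` carries a different core, and how this core differs from that of compound 2 is not broken down here. In this assay compound 3 reaches only a limit, > 20 mg/kg, which is the limit of > 20 mg/kg in this assay, at which 1 of the 3 values shown sits. Compound 4 `CCC(CC)N/C(=N\O)Nc1cccnc1` arises from compound 3 by pentan-3-yl in place of 1,1-dimethylpropyl on an amine nitrogen; this is the same kind of change as from compound 2 to compound 1, though there the group sits on a double-bonded nitrogen and here on an amine nitrogen. Compound 4 is expected to show a step that the limit leaves unreadable from compound 3 to compound 4 because the matching step no change at the digits printed from compound 2 to compound 1 (within the scatter). The estimate for compound 4 in this assay is therefore 30 mg/kg, very likely again only a limit.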

Compound 4, minimum effective dose: 50 mg/kg
Compound 4: middle estimate off by 1.7-fold (0.22 log units), on the low side; low and high end bracket the measured number.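

Compound 3 stands only at a limit, so no step from it to compound 4 can be read: the limit of > 20 mg/kg in this assay, at which 1 of the 4 values shown sits.

The compounds shown leave open whether pentan-3-yl in place of 1,1-dimethylpropyl on an amine nitrogen changes anything on this core in this assay.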